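The compounds below may be only part of what the source reports. "The series", "measured", "known", "first", "only" and "open" are said of these compounds alone.

Measured compounds:
- compound 1, `Cc1n[nH]c(C(=O)O)c1Cc1ccc(C(F)(F)F)cc1`, giving 9% in an assay on isolated protein for inhibition of 2-Hydroxyacid oxidase 2 (Homo sapiens), tested at 1 uM; a higher number here means a stronger effect of the compound at the concentration tested, a lower number a weaker effect
- compound 2, `Cc1n[nH]c(C(=O)O)c1Cc1ccc(C#N)cc1`, giving 0% in this assay

Among the compounds with values here, compound 2 stands lowest of the two numbers measured so far in this assay, and its nearest neighbour is compound 1, though the two lie within the scatter of each other. Within the data shown here, the only step measured between the two, a number 9 percentage points lower from compound 1 to compound 2 (within the scatter), therefore shows no effect that can be told from the scatter.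

Compound 3, `Cc1n[nH]c(C(=O)O)c1Cc1ccc(C(N)=O)cc1`, has not yet been measured. It differs from compound 2 in one place: carbamoyl in place of cyano on an aromatic carbon. The step measured so far swapped one small group for another on the same aromatic carbon and left the read-out essentially where it was, and both measured numbers sit near the bottom of the scale. Nothing in these two values points to a change beyond the scatter for this assay, in either direction. The expected step is a number 4 percentage points higher from compound 2 to compound 3 (within the scatter), that is, no movement that could be told from repeated measurements. For compound 3 the estimated value in this assay is 4%, with a range from -8% to 20%.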

Compound 3, a percentage reported as inhibition, at one concentration (the size of the read-out at that concentration, not a potency): 0%
Beside the measured number, compound 3's estimate is 4 percentage points above it, and the stated range covers the measured number.
By their numbers in this assay, from the lowest: compounds 2, 3 and 1 (each within the scatter of the next).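

In this assay, carbamoyl on the aromatic carbon para to a large group gives no change at the digits printed from compound 2 to compound 3 (within the scatter) when it replaces cyano, and a number 9 percentage points lower from compound 1 to compound 3 (within the scatter) when it replaces trifluoromethyl. Within the data shown here, the earlier pair compared only cyano and trifluoromethyl, whereas carbamoyl carries a hydrogen-bond donor that cyano lacks and has one more heavy atom, yet these differences produce no step that can be told from the scatter. No independent measurement is available to explain why the three compounds cannot be separated here.

On these data alone, whether any group at this position can raise the read-out beyond the scatter remains open, for example an amine, a carboxylic acid or a longer chain such as an ethoxyethyl group on the same aromatic carbon. Also open is whether changes elsewhere on the shared core would matter more, and since each number comes from a single concentration, none of these compounds has a potency that can be stated.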